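Dithiocarbamate benzamides: antiproliferative read-out, compound 4

A few compounds are considered here, and "the series" means these few. Any claim that something is new, unique, unknown or untested is made for them only; others in the source may bear on it.

Measured compounds:
compound 1 `Nc1ccccc1NC(=O)c1ccc(CSC(=S)N2CCN(C3CCCCC3)CC2)cc1` 30.6%
compound 2 `Nc1ccccc1NC(=O)c1ccc(CSC(=S)N2CCN(Cc3ccncc3)CC2)cc1` 59.5%
compound 3 `Nc1ccccc1NC(=O)c1ccc(CSC(=S)N2CCN(Cc3ccccc3)CC2)cc1` 20.6%

In a functional assay on HeLa cells (Homo sapiens) for antiproliferative activity, read by CCK-8 assay, with a stated time of 72 h, tested at 2 uM (on this read-out lower numbers stand for a weaker effect and higher numbers for a stronger effect at the one concentration tested), compound 3 gives the lowest of the three numbers. Its nearest neighbour is compound 1, and the step of a number 10 percentage points lower from compound 1 to compound 3 (within the scatter) lies within the scatter, so the two cannot be ordered. Within the data shown here, the only compound set apart is compound 2, with the step of a number 38.9 percentage points lower from compound 2 to compound 3 (beyond the scatter) beyond the scatter, and likewise a number 28.9 percentage points higher from compound 1 to compound 2 (beyond the scatter).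

Compound 4 `Nc1ccccc1NC(=O)c1ccc(CSC(=S)N2CCN(c3ccccc3F)CC2)cc1` differs from compound 3 at the same position that varies across the series: 2-fluorophenyl in place of benzyl on an amine nitrogen in a ring.

Among the measured compounds shown here, no measured step puts an aromatic ring directly on the ring nitrogen, so none bears on this change exactly. The steps that exist compare a cyclohexyl, a benzyl and a (pyridin-4-yl)methyl there; the two carbon-only groups, in compound 1 and compound 3, sit within the scatter of each other, and only the pyridin-4-yl-bearing compound 2 stands out. Compound 4 keeps a carbon-only ring, so no move beyond the scatter is expected, though the direct attachment of the ring leaves the guess uncertain. For compound 4 in this assay the estimate is 25%, with a range of 8% to 48%, which means an expected step of a number 4.4 percentage points higher from compound 3 to compound 4 (within the scatter).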

Compound 4, a percentage reported as inhibition, at one concentration (the size of the read-out at that concentration, not a potency): 17.5%
The estimate for compound 4 lay 7.5 percentage points above the measured number; the range from low to high includes it.
By their numbers in this assay, from the lowest: compounds 4, 3 and 1 (each within the scatter of the next, the first and the last beyond it); then compound 2.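

In this assay the exchange of benzyl for 2-fluorophenyl on the amine nitrogen in the ring gives a number 3.1 percentage points lower from compound 3 to compound 4 (within the scatter) and so leaves the two compounds unordered, which shows that an aromatic ring can stand on this nitrogen without its own linking carbon and without a separation from the benzyl compound. Among these compounds, the 2-fluorophenyl compound also stays far from the pyridine-bearing compound, with a number 42 percentage points lower from compound 2 to compound 4 (beyond the scatter) as the largest gap so far, and it gives the first separation among the carbon-only groups, with a number 13.1 percentage points lower from compound 1 to compound 4 (beyond the scatter) as a modest step that compound 3 does not share, since compound 3 lies within the scatter of both neighbours. No measurement at hand accounts for any of these steps.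

Plain phenyl on the same nitrogen would be needed to tell what the fluorine contributes to the 2-fluorophenyl result. Pyridin-4-yl placed directly on that nitrogen, or a (pyridin-3-yl)methyl group, would show whether the high number of compound 2 depends on the linking carbon or on where the nitrogen sits in the ring.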